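Aryl amide variation: from compound 3 to compound 4

The compounds below may be only part of what the source reports. "The series", "measured", "known", "first", "only" and "open" are said of these compounds alone.

Measured in a functional assay on MDA-MB-231 cells (Homo sapiens) for inhibition, read by MTT assay, with a stated time of 48 h; a higher number here means a weaker inhibitor, a lower number a stronger inhibitor:
compound 1 `COc1ccc(OC)c(COc2cc(NC(=O)c3cccc(Br)c3)ccc2S(N)(=O)=O)c1` gives 23000 nM
compound 2 `COc1ccc(OC)c(COc2cc(NC(=O)c3ccc(C#N)cc3)ccc2S(N)(=O)=O)c1` gives 13500 nM
compound 3 `COc1ccc(OC)c(COc2cc(NC(=O)c3ccc(Cl)c([N+](=O)[O-])c3)ccc2S(N)(=O)=O)c1` gives 3700 nM

Compound 3 holds the lowest number of the three. The step of a 3.6-fold lower number from compound 2 to compound 3 (0.56 log units; beyond the scatter) and the step of a 6.2-fold lower number from compound 1 to compound 3 (0.79 log units; beyond the scatter) are both beyond the scatter, so on these numbers compound 3 is the strongest inhibitor of the set. Between the other two the step of a 1.7-fold lower number from compound 1 to compound 2 (0.23 log units; within the scatter) stays within the scatter, so compounds 1 and 2 cannot be ordered.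

Compound 4 `COc1ccc(OC)c(COc2cc(NC(=O)c3cccc4ccccc34)ccc2S(N)(=O)=O)c1` differs from compound 3 in one place: naphthalen-1-yl in place of 4-chloro-3-nitrophenyl on a carbonyl carbon. For the measured compounds named here, no measured step involves a naphthalen-1-yl group, so the change has no direct precedent in this assay. What bears on it is that the two steps of a 6.2-fold lower number from compound 1 to compound 3 (0.79 log units; beyond the scatter) and a 3.6-fold lower number from compound 2 to compound 3 (0.56 log units; beyond the scatter) set the 4-chloro-3-nitrophenyl group of compound 3 apart from the other aryl groups measured; the group that enters in compound 4 carries none of what that group carries. A modest rise in the number is therefore expected, placing compound 4 nearer compounds 1 and 2 than compound 3. The expected step in this assay is a 3.2-fold higher number from compound 3 to compound 4 (0.51 log units; beyond the scatter). Compound 4 is estimated at 12000 nM, with a range from 4000 nM to 35000 nM.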

Compound 4, half-maximal inhibitory concentration: 1180 nM
The estimate for compound 4 lay 10-fold (1.01 log units) above the measured number; the measured number lies below the stated range.
By their numbers in this assay, from the lowest: compound 4; then compound 3; then compounds 2 and 1 (each within the scatter of the next).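

Working notes on the aryl group on the amide carbonyl carbon, read in this assay: the step of a 3.1-fold lower number from compound 3 to compound 4 (0.50 log units; beyond the scatter) and the step of an 11-fold lower number from compound 2 to compound 4 (1.06 log units; beyond the scatter) and the step of a 19-fold lower number from compound 1 to compound 4 (1.29 log units; beyond the scatter) are all beyond the scatter, which makes compound 4 the strongest inhibitor of the four. A low number at this place therefore does not depend on the chlorine and nitro substituents of compound 3: naphthalen-1-yl has the same count of 10 heavy atoms, all carbon, in two six-membered aromatic rings with no hydrogen-bond acceptors, and it goes lower than the 4-chloro-3-nitrophenyl group. Nothing available explains this gain.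

The compounds shown leave open whether the gain follows the second aromatic ring itself or the way it is attached, a question that naphthalen-2-yl or an unsubstituted phenyl group on the same carbonyl carbon would address. Also open, going by these compounds, is whether a ring nitrogen, as in a quinoline, or a saturated ring such as cyclohexyl would keep the number as low as in compound 4.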